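A few compounds are considered here, and "the series" means these few. Any claim that something is new, unique, unknown or untested is made for them only; others in the source may bear on it.

In a functional assay on KB cells (Homo sapiens) for antiproliferative activity, read by sulforhodamine B assay, with a stated time of 48 h (on this read-out lower numbers stand for stronger inhibition of growth and higher numbers for weaker inhibition of growth), compound 1 (`Nc1ccccc1NC(=O)c1ccc(CCc2ccccc2NS(=O)(=O)c2ccccc2)cc1`) gives 456 nM and compound 2 (`COc1ccc(S(=O)(=O)Nc2ccccc2CCc2ccc(C(=O)Nc3ccccc3O)cc2)cc1`) gives 472 nM, so these two values lie within the scatter of each other. Compound 3 (`Nc1ccccc1NC(=O)c1ccc(CCc2ccccc2)cc1`) differs from compound 1 by hydrogen in place of (phenylsulfonyl)amino on an aromatic carbon. Among the compounds with values here, no measured pair shows a comparable change, so the expectation rests on the structural change alone. Weaker inhibition of growth, beyond the scatter, is expected, with an estimated step of a 4.4-fold higher number from compound 1 to compound 3 (0.64 log units; beyond the scatter). For compound 3 the estimated value is 2000 nM, with an expected range of 600 nM to 7000 nM.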

Compound 3, concentration for 50% growth inhibition: > 10000 nM
Compound 3 ended at the assay's limit (the forecaster's own chance of this, stated with the estimate: 10%); middle value at least 5.0-fold (0.69 log units) from the limit.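

Hydrogen in place of (phenylsulfonyl)amino on this aromatic carbon gives an at least 21-fold higher number from compound 1 to compound 3 (1.34 log units; beyond the scatter) in this assay. Growth inhibition by compound 1 therefore depends on this group at this position, which the two earlier values could not show. Compound 3 gives > 10000 nM, which is a limit of the assay and not a number: the limit of > 10000 nM in this assay, at which 1 of the 3 values shown sits.

On these data alone, the full size of the step remains open. Also open, as far as these compounds go, is whether a simple amine or an acetamide on this carbon would keep the inhibition, and so whether the whole (phenylsulfonyl)amino group is needed.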